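Phenyl in Place of Octyl in a Weak Inhibitor Pair

The source may report more compounds than this note shows. Statements on the series, on what has been measured and on what is new or still open speak of the compounds shown alone.

Compound 1, `CCCCCCCCNC(=S)N1C[C@H](NC(C)=O)[C@H](O)[C@H](O)[C@H]1CO`: 350000 nM
Compound 2, `CCCCCCCC/N=C1\SC[C@@H]2[C@@H](O)[C@@H](O)[C@@H](NC(C)=O)CN12`: 100000 nM

In an assay for inhibition of beta-hexosaminidase subunit alpha (Homo sapiens), read by fluorescence (on this read-out higher numbers stand for weaker inhibition and lower numbers for stronger inhibition), compound 1 gives 350000 nM, while compound 2 gives 100000 nM, the lower of the two numbers, and that gap lies beyond the usual scatter. Compound 3, `CC(=O)N[C@H]1CN2/C(=N/c3ccccc3)SC[C@@H]2[C@@H](O)[C@H]1O`, is not yet measured; it differs from compound 2 by phenyl in place of octyl on a double-bonded nitrogen. Among the measured compounds shown here, no measured pair shows a change of this kind here, so its direction is open. Compound 3 is expected to give about 200000 nM, somewhere from 50000 nM to 1000000 nM. The expected step of a 2.0-fold higher number from compound 2 to compound 3 (0.30 log units; within the scatter) would stay within the scatter or slightly weaken inhibition.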

Compound 3, half-maximal inhibitory concentration: 100000 nM
The estimate for compound 3 lay 2.0-fold (0.30 log units) above the measured number, within the range that was stated.
By their numbers in this assay, from the lowest: compounds 2 and 3 (each within the scatter of the next); then compound 1.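

Phenyl in place of octyl on the double-bonded nitrogen gives no change at the digits printed from compound 2 to compound 3 (within the scatter) in this assay. At this position, then, a six-membered aromatic ring of carbon can stand in for an open octyl chain without moving the number beyond the scatter, so these two groups cannot be told apart in this assay. Nothing available accounts for why the two groups read alike.

Still open, going by these compounds, is whether a shorter chain such as butyl would also read the same on this nitrogen. Equally open, on these data alone, is whether a phenyl ring carrying an amine or a carboxylic acid would shift the number beyond the scatter.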